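The source may report more compounds than this note shows. Statements on the series, on what has been measured and on what is new or still open speak of the compounds shown alone.

Of the compounds shown here, three sharing one core have been measured in an ADME assay on MCF-10A cells (Homo sapiens) for cytotoxicity, read by sulforhodamine B assay, with a stated time of 48 h; a lower number here means a stronger inhibitor of growth, a higher number a weaker inhibitor of growth. For the measured compounds named here, compound 1 `O=C1C(=O)N(CN2CCCCC2)c2cccc(Cl)c21` gives 70700 nM, and compound 2 `CCN(CC)CN1C(=O)C(=O)c2c(Cl)cccc21` gives 35000 nM; the single one-point change among them is a 2.0-fold lower number from compound 1 to compound 2 (0.31 log units; beyond the scatter). Compound 3 `CN(C)CN1C(=O)C(=O)c2ccccc21` gives 150000 nM, the highest number of the three, so it is the weakest growth inhibitor of this set. Compound 4 `CN(C)CN1C(=O)C(=O)c2c(Cl)cccc21` differs from compound 3 by chloro in place of hydrogen on an aromatic carbon. Going by the values given here, no measured step shows this change alone; compounds 1 and 2 both carry the chloro group and sit below compound 3, but each also differs from compound 3 elsewhere, so they bear on the question only loosely. The number for compound 4 is expected to be lower, a 3.0-fold lower number from compound 3 to compound 4 (0.48 log units; beyond the scatter), with wide uncertainty. Compound 4 is estimated at 50000 nM, ranging from 20000 nM to 150000 nM.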

Compound 4, concentration for 50% growth inhibition: 82300 nM
Beside the measured number, compound 4's estimate is 1.6-fold (0.22 log units) below it; the range from low to high includes it.
By their numbers in this assay, from the lowest: compound 2; then compounds 1, 4 and 3 (each within the scatter of the next, the first and the last beyond it).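

In this assay, chloro in place of hydrogen on this aromatic carbon gives a 1.8-fold lower number from compound 3 to compound 4 (0.26 log units; within the scatter) and so cannot be told apart from the usual scatter of repeats. With chloro present in all three compounds, dimethylamino in place of diethylamino gives a 2.4-fold higher number from compound 2 to compound 4 (0.37 log units; beyond the scatter) and dimethylamino in place of piperidin-1-yl gives a 1.2-fold higher number from compound 1 to compound 4 (0.07 log units; within the scatter) on the same chain carbon. Nothing available explains these steps. Still open, as far as these compounds go, is how bromo or methoxy on this aromatic carbon would compare. Also open, from the compounds shown here alone, is whether chloro in place of hydrogen gives a similar step with diethylamino or piperidin-1-yl on the chain.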